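Moving From 2-Bromophenyl to 4-Fluorophenyl at the Assay Limit

The source may hold more compounds than are shown below. What is called first, only, known or untested is meant among the compounds shown, and "the series" means these compounds.

In a functional assay on HL-60 cells (Homo sapiens) for antiproliferative activity, read by sulforhodamine B assay, with a stated time of 72 h (on this read-out lower numbers stand for stronger inhibition and higher numbers for weaker inhibition), compound 1 (`Fc1ccccc1NC(=S)N/N=C/c1ccc2ccccc2n1`) gives > 100000 nM, which is a limit and not a number. Compound 2 (`NC(=S)N/N=C/c1ccc2ccccc2n1`) gives > 100000 nM, again a limit. Compound 3 (`S=C(N/N=C/c1ccc2ccccc2n1)Nc1ccccc1Br`) gives > 100000 nM, also a limit, so it has no exact value. All three therefore sit at the limit of > 100000 nM in this assay, at which 3 of the 3 values shown sit. Compound 4 (`Fc1ccc(NC(=S)N/N=C/c2ccc3ccccc3n2)cc1`) carries 4-fluorophenyl in place of 2-bromophenyl on an amide-type nitrogen. The steps closest to this change are a step that the two limits leave unreadable from compound 1 to compound 3 and a step that the two limits leave unreadable from compound 2 to compound 3, and neither gives a size to build on. No step beyond the scatter is expected, and the estimated change is a number no higher from compound 3 to compound 4 (the limit leaves the size open). Compound 4 is expected at 100000 nM, with an estimated range of 20000 nM to 200000 nM.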

Compound 4, half-maximal inhibitory concentration: 17000 nM
The estimate for compound 4 lay 5.9-fold (0.77 log units) above the measured number, and the stated range ends above it.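

In this assay, 4-fluorophenyl on the amide-type nitrogen gives the only readable number among these compounds: the limit of > 100000 nM in this assay, at which 3 of the 4 values shown sit. Replacing 2-bromophenyl gives an at least 5.8-fold lower number from compound 3 to compound 4 (0.76 log units; beyond the scatter), replacing hydrogen gives an at least 5.8-fold lower number from compound 2 to compound 4 (0.76 log units; beyond the scatter), and replacing 2-fluorophenyl gives an at least 5.8-fold lower number from compound 1 to compound 4 (0.76 log units; beyond the scatter). A phenyl ring on this nitrogen is therefore not enough on its own, as 2-fluorophenyl and 4-fluorophenyl, which differ only in where the fluorine sits, do not give the same result.

On these data alone, each of these steps is a minimum, so their true sizes remain open. Also open, as far as these compounds go, is how 4-bromophenyl or 4-methoxyphenyl would behave at this position.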